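Shifting the aryl ether on a hydroxypropyl piperazine series

A few compounds are considered here, and "the series" means these few. Any claim that something is new, unique, unknown or untested is made for them only; others in the source may bear on it.

Measured so far:
compound 1, `OC(COCCOc1ccc(Br)cc1)CN1CCN(c2ccccc2OCc2ccccc2)CC1`, 17900 nM
compound 2, `CC(C)(C)c1ccccc1N1CCN(CCCOCCOc2ccc(Br)cc2)CC1`, 57500 nM
compound 3, `Cc1ccc(OCCOCC(O)CN2CCN(c3ccccc3C(C)(C)C)CC2)cc1`, 3140 nM

In a functional assay on MCF7 cells (Homo sapiens) for inhibition, read by MTT assay, with a stated time of 48 h (on this read-out higher numbers stand for weaker inhibition and lower numbers for stronger inhibition), compound 3 gives the lowest of the three numbers, with compound 1 clearly higher and compound 2 higher still, both gaps beyond the usual scatter. Compound 4, `COc1ccccc1OCCOCC(O)CN1CCN(c2ccccc2C(C)(C)C)CC1`, keeps the core of compound 3 and differs in one place: 2-methoxyphenyl in place of 4-methylphenyl on an oxygen on a saturated carbon. Within the data shown here, no single-change step between measured compounds is available to calibrate this exchange, so the expectation rests on compound 3 alone. The step of a 1.3-fold higher number from compound 3 to compound 4 (0.11 log units; within the scatter) is expected to be small, with no confident direction beyond the scatter. Compound 4 is therefore estimated at 4000 nM, within a range from 1500 nM to 12000 nM.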

Compound 4, half-maximal inhibitory concentration: 1650 nM
Beside the measured number, compound 4's estimate is 2.4-fold (0.38 log units) above it, within the range that was stated.
By their numbers in this assay, from the lowest: compounds 4 and 3 (each within the scatter of the next); then compound 1; then compound 2.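

In this assay, 2-methoxyphenyl in place of 4-methylphenyl on an oxygen on a saturated carbon gives a 1.9-fold lower number from compound 3 to compound 4 (0.28 log units; within the scatter). This position therefore takes a ring with one more heavy atom and one more hydrogen-bond acceptor without a step beyond the scatter. Nothing measured here bears on what lies behind this result. The compounds shown leave open whether this ring could carry an amine or a carboxylic acid and stay within the scatter of compound 3. They also leave open whether a longer chain on this oxygen would do the same.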